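Chain extension on two oxazole cores with a dead starting point

A few compounds are considered here, and "the series" means these few. Any claim that something is new, unique, unknown or untested is made for them only; others in the source may bear on it.

Compound 1 `COc1cccc(N2CCN(C(=O)c3oc(C)nc3-c3ccccc3)CC2)c1` was tested in a functional assay on HL-60 cells (Homo sapiens) for inhibition, read by MTT assay, with a stated time of 72 h (on this read-out lower numbers stand for stronger inhibition and higher numbers for weaker inhibition), where compound 1 gives 34.8 nM. Its analog compound 2 `CCOc1cccc(N2CCN(C(=O)c3oc(C)nc3-c3ccccc3)CC2)c1` carries methyl in place of hydrogen on a saturated chain carbon bound to an oxygen on an aromatic ring; in this assay compound 2 gives 151 nM, and the step shows a 4.3-fold higher number from compound 1 to compound 2 (0.64 log units; beyond the scatter). Compound 3 `CCc1nc(-c2ccc(OC)c(OC)c2)c(C(=O)N2CCN(c3cccc(Cl)c3)CC2)o1` rests on a different core; the difference between the two cores is not broken down here. In this assay compound 3 gives "not active" (no number reported), with no number given. Compound 4 `CCCc1nc(-c2ccc(OC)c(OC)c2)c(C(=O)N2CCN(c3cccc(Cl)c3)CC2)o1` differs from compound 3 by methyl in place of hydrogen on a saturated chain carbon, two bonds along the chain from an aromatic carbon. This is the same kind of change as between compound 1 and compound 2, but around a different place: there on a saturated chain carbon bound to an oxygen on an aromatic ring, here two bonds along the chain from an aromatic carbon. Since compound 3 showed no activity, compound 4 is expected to remain weak, with an estimated 30000 nM and a range from 5000 nM to 150000 nM.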

Compound 4, half-maximal inhibitory concentration: "not active" (no number reported)
Compound 4 has no reported number here; there is nothing to compare the estimate with.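

Neither compound 3 nor compound 4 has a number in this assay and no step can be read between them. The compounds shown leave open whether methyl in place of hydrogen at this place changes activity on their shared core. No evidence bears on this result.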